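Aryl sulfonate series: varying the phenoxy group of compound 3

The compounds below may be only part of what the source reports. "The series", "measured", "known", "first", "only" and "open" are said of these compounds alone.

In a functional assay on MCF7 cells (Homo sapiens) for antiproliferative activity, read by sulforhodamine B assay, with a stated time of 48 h (on this read-out higher numbers stand for weaker inhibition and lower numbers for stronger inhibition), compound 3 `CCCN1CCN(c2ccc(S(=O)(=O)Oc3ccccc3CC)cc2)C1=O` gives 2300 nM, the lowest of the two numbers shown. Compound 1 `CCc1ccccc1OS(=O)(=O)c1ccc(N2CCN(C)C2=O)cc1` gives 26000 nM. Compound 2 `CN1CCN(c2ccc(S(=O)(=O)Oc3cccc(F)c3)cc2)C1=O` returns only a limit, > 100000 nM (the limit of > 100000 nM in this assay, at which 1 of the 3 values shown sits). The step of an 11-fold lower number from compound 1 to compound 3 (1.05 log units; beyond the scatter) is large, whereas an at least 3.8-fold higher number from compound 1 to compound 2 (0.58 log units; beyond the scatter) runs in the opposite direction. Compound 4 `CCCN1CCN(c2ccc(S(=O)(=O)Oc3ccc(OC)cc3)cc2)C1=O` has not yet been measured; it differs from compound 3 by 4-methoxyphenyl in place of 2-ethylphenyl on an oxygen. Going by the values given here, the only measured step that touches the aryl on the oxygen is an at least 3.8-fold higher number from compound 1 to compound 2 (0.58 log units; beyond the scatter), so a rising number, meaning weaker inhibition, is expected here as well. For compound 4 the expected step is a 6.5-fold higher number from compound 3 to compound 4 (0.81 log units; beyond the scatter). Compound 4 is therefore estimated at 15000 nM, with an expected range from 4000 nM to 60000 nM.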

Compound 4, half-maximal inhibitory concentration: 20000 nM
The estimate for compound 4 lay 1.3-fold (0.12 log units) below the measured number, within the range that was stated.
By their numbers in this assay, from the lowest: compound 3; then compounds 4 and 1 (each within the scatter of the next). At a limit, above all of these: compound 2.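

In this assay, replacing 2-ethylphenyl on this oxygen costs activity even with the propyl chain in place: an 8.7-fold higher number from compound 3 to compound 4 (0.94 log units; beyond the scatter). The earlier step at this place, an at least 3.8-fold higher number from compound 1 to compound 2 (0.58 log units; beyond the scatter), rested on a limit, whereas this one has a number at both ends and runs the same way. No measured property among the data bears on this rise.

The change swaps the group and where it sits at once, so ethyl and methoxy cannot be separated here. On these data alone, how an amine or a carboxylic acid on that phenyl would read stays open.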